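Cytotoxicity notes on compound 1 and compound 3

This account rests on a few compounds, and the source may have more. Where it says the series, first, only, none or still open, it means among the compounds named here.

Measured so far:
compound 1 `O=C(Nc1cc(F)c(F)c(F)c1)N1Cc2c(-c3ccc(F)cc3F)cnn2CC1C1CC1`: 32100 nM
compound 2 `C[C@H]1Cn2ncc(N3CC(c4ccccc4)CC3=O)c2CN1C(=O)NCc1cc(F)c(F)c(F)c1`: > 2000 nM

Within the data shown here, compound 1 stands alone as the one compound with a number in a toxicity assay on HepG2 2.2.15 cells (Homo sapiens) for cytotoxicity, read by CellTiter-Glo (a lower number here means that less compound is tolerated, a higher number that more compound is tolerated), where compound 1 gives 32100 nM. Compound 2 gives only a limit of the assay in this assay, > 2000 nM, and not a number; this is the limit of > 2000 nM in this assay, at which 1 of the 2 values shown sits.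

Compound 3 `O=C1CC(c2ncco2)CN1c1cnn2c1CN(C(=O)Nc1cc(F)c(F)c(F)c1)C(C1CC1)C2` is not yet measured. It differs from compound 1 in one place: 4-(1,3-oxazol-2-yl)-2-oxopyrrolidin-1-yl in place of 2,4-difluorophenyl on an aromatic carbon. Among the measured compounds shown here, no pair of measured compounds differing in one place is available, so the size of this change cannot be read from any measured step. For compound 3 a step of a 1.4-fold higher number from compound 1 to compound 3 (0.15 log units; within the scatter) in this assay is expected, toward more compound tolerated, of a size at or a little beyond the scatter. Compound 3 is estimated at 45000 nM, with a range from 15000 nM to 120000 nM.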

Compound 3, half-maximal cytotoxic concentration: > 200000 nM
Compound 3 gave a limit, no number (the forecaster's own chance of this, stated with the estimate: 30%); middle value at least 4.4-fold (0.64 log units) from the limit.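

In this assay, compound 3 gives a limit of the assay and not a number: the limit of > 200000 nM in this assay, at which 1 of the 3 values shown sits.

Placing 4-(1,3-oxazol-2-yl)-2-oxopyrrolidin-1-yl in place of 2,4-difluorophenyl on this aromatic carbon gives an at least 6.2-fold higher number from compound 1 to compound 3 (0.79 log units; beyond the scatter), the first measured step in the series and one that moves toward more compound tolerated. This shows that the aromatic carbon of the five-membered aromatic ring with 2 nitrogen can carry a substituent other than 2,4-difluorophenyl, and that the change there shifts the read-out beyond the scatter.

Going by these compounds, whether the step comes from the loss of the 2,4-difluorophenyl, from the 2-oxopyrrolidine ring or from the oxazole remains open. Also open, on these data alone, is how a 2-oxopyrrolidin-1-yl without the oxazole, or a morpholine on the same carbon, would read in this assay.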